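The source may report more compounds than this note shows. Statements on the series, on what has been measured and on what is new or still open speak of the compounds shown alone.

The measured compounds and their read-outs:

Compound 1 `COc1ccc(-c2nc(C)c(C(=O)CSc3nc(-c4ccc(OC)cc4)c(C#N)c(=O)[nH]3)s2)cc1` gives 11.5% in a functional assay on U-87MG ATCC cells for antiproliferative activity against U-87 MG (Homo sapiens), read by MTT assay, with a stated time of 48 h, tested at 100 uM; a lower number here means a stronger effect, a higher number a weaker effect of the compound at the concentration tested.
Compound 2 `Cc1nc(-c2ccc(Cl)cc2)sc1C(=O)CSc1nc(-c2ccc(Cl)c(Cl)c2)c(C#N)c(=O)[nH]1` gives 36.5% in this assay.
Compound 3 `Cc1nc(-c2ccc(Cl)cc2)sc1C(=O)CSc1nc(-c2cccc(Cl)c2)c(C#N)c(=O)[nH]1` gives 12.5% in this assay.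

Among these three numbers, compound 3 stands close to compound 1, the two lying within the usual scatter of each other, while compound 2 sits further away with a higher number, a gap beyond the scatter. Within the data shown here, the one single-point step recorded, a number 24 percentage points lower from compound 2 to compound 3 (beyond the scatter), shows the size that removing a chloro from the ring attached to the core can bring.

Compound 4 `COc1ccc(-c2nc(SCC(=O)c3sc(-c4ccc(Cl)cc4)nc3C)[nH]c(=O)c2C#N)cc1` differs from compound 3 in one place: 4-methoxyphenyl in place of 3-chlorophenyl on an aromatic carbon. Among the measured compounds shown here, no measured step swaps these two groups at this position, so the step from compound 2 to compound 3 bears on it only loosely. Compound 1, carrying the same 4-methoxyphenyl at this position, gives 11.5%, a number within the scatter of compound 3. Compound 4 is therefore expected to give about 14%, between 5% and 30%. That estimate corresponds to an expected step of a number 1.5 percentage points higher from compound 3 to compound 4 (within the scatter), which is not expected to exceed the scatter.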

Compound 4, a percentage reported as activity, at one concentration (the size of the read-out at that concentration, not a potency): 16.6%
For compound 4 the middle estimate is 2.6 percentage points below the measured one, within the range that was stated.
By their numbers in this assay, from the lowest: compounds 1, 3 and 4 (each within the scatter of the next); then compound 2.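

In this assay the step of 4-methoxyphenyl in place of 3-chlorophenyl on the aromatic carbon ortho to a cyano group is a number 4.1 percentage points higher from compound 3 to compound 4 (within the scatter) and thus shows that these two groups cannot be told apart at this position. With 4-methoxyphenyl in place of 3,4-dichlorophenyl the step is a number 19.9 percentage points lower from compound 2 to compound 4 (beyond the scatter) and so, among compounds 2, 3 and 4, the 3,4-dichlorophenyl group alone stands apart at this position. At a second place, chloro in place of methoxy gives a number 5.1 percentage points higher from compound 1 to compound 4 (within the scatter) and adds a first reading there, one that also cannot be told from no change.

On these data alone, whether an amine or a carboxylic acid at this position, or a longer chain in place of the methoxy, would move the number beyond the scatter remains open. Nothing at hand explains why the 3,4-dichlorophenyl group stands apart.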